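Stretching the Chain to the Hydroxy Group: Compound 4

The source may hold more compounds than are shown below. What is called first, only, known or untested is meant among the compounds shown, and "the series" means these compounds.

Compound 1 `OCCNCc1nc2c(OCC3CCCCC3)cccc2[nH]1` gives 63.3% in an assay on cells for inhibition of interleukin-5 receptor subunit alpha (Mus musculus), read by WST assay, with a stated time of 48 h, tested at 30 uM, in the presence of a further agent that is not named here; on this read-out higher numbers stand for more inhibition at the one concentration tested (going by the name of the read-out) and lower numbers for less inhibition.
Compound 2 `OCCCNCc1nc2c(OCC3CCCCC3)cccc2[nH]1` gives 52.7% in this assay.
Compound 3 `OCCCCNCc1nc2c(OCC3CCCCC3)cccc2[nH]1` gives 44.3% in this assay.

Compound 3 holds the lowest of the three numbers: its gap to compound 2 is within the scatter, while a number 19 percentage points lower from compound 1 to compound 3 (beyond the scatter) lies beyond it. Compound 4 `OCCCCCNCc1nc2c(OCC3CCCCC3)cccc2[nH]1` differs from compound 3 by hydroxymethyl in place of hydroxy on a saturated chain carbon, four bonds along the chain from an amine nitrogen. The same kind of change has been seen twice already along this series: a number 10.6 percentage points lower from compound 1 to compound 2 (beyond the scatter), beyond the scatter, and a number 8.4 percentage points lower from compound 2 to compound 3 (within the scatter), within it; together they add up to a number 19 percentage points lower from compound 1 to compound 3 (beyond the scatter). Among the measured compounds shown here, the numbers run downward as the chain grows, with only the steps from compound 1 beyond the scatter, so a further small downward step in this assay is expected for the next link, with a fair chance that it again falls within the scatter. Compound 4 is therefore expected to give 37%, within a range of 24% to 50%, which corresponds to an expected step of a number 7.3 percentage points lower from compound 3 to compound 4 (within the scatter).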

Compound 4, a percentage reported as inhibition, at one concentration (the size of the read-out at that concentration, not a potency): 23.7%
For compound 4 the middle estimate is 13.3 percentage points above the measured one; the whole stated range lies above it.
By their numbers in this assay, from the lowest: compound 4; then compounds 3 and 2 (each within the scatter of the next); then compound 1.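

Compound 4 shows that the loss in this assay does not level off as the chain to the hydroxy group grows: the added link at this place, four bonds along the chain from an amine nitrogen, gives a number 20.6 percentage points lower from compound 3 to compound 4 (beyond the scatter). Over the longer spans the change gives a number 29 percentage points lower from compound 2 to compound 4 (beyond the scatter) and a number 39.6 percentage points lower from compound 1 to compound 4 (beyond the scatter), which puts compound 4 below the other three compounds, each gap beyond the scatter. Set against the first one-link step, this drop is no clear departure from what the same change did before: the same change on two cores in this assay, a number 10.6 percentage points lower (beyond the scatter) from compound 1 to compound 2 and a number 20.6 percentage points lower (beyond the scatter) from compound 3 to compound 4, 10 percentage points apart, within the scatter of two such steps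

The compounds shown leave open whether a still longer chain would lower the number further. They also cannot separate the effect of chain length from that of the terminal hydroxy group, which an amine or a carboxylic acid at the chain end, or a plain alkyl chain, could test.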